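The source may report more compounds than this note shows. Statements on the series, on what has been measured and on what is new or still open speak of the compounds shown alone.

compound 1 `O=c1nc2ccc(Br)cn2cc1Cc1ccc(Br)cc1` gives 870 nM in a functional assay on SK-N-SH cells (Homo sapiens) for cytotoxicity, read by MTT assay, with a stated time of 24 h; a higher number here means a weaker inhibitor, a lower number a stronger inhibitor
compound 2 `COc1ccc(Cc2cn3cc(Br)ccc3nc2=O)cc1` gives 940 nM in this assay
compound 3 `Nc1cccn2cc(Cc3ccc(F)cc3)c(=O)nc12` gives 126000 nM in this assay

Compound 2 is second highest of the three numbers. It lies within the scatter of compound 1, and compound 3 lies far higher. Compound 4 `O=c1nc2ccc(Br)cn2cc1Cc1ccc(Cl)cc1` follows from compound 2 by chloro in place of methoxy on an aromatic carbon with chloro in place of methoxy on an aromatic carbon, para to a large group. Among the measured compounds shown here, the one measured step that bears on this is a 1.1-fold higher number from compound 1 to compound 2 (0.03 log units; within the scatter) and it exchanges bromo for methoxy on that same carbon. Compound 3 differs in more than one place and gives no guide. No change beyond the scatter is expected, and the estimated step is a 1.0-fold lower number from compound 2 to compound 4 (0.02 log units; within the scatter) in either direction. Compound 4 is expected at 900 nM (400 nM to 2000 nM).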

Compound 4, half-maximal inhibitory concentration: 940 nM
Compound 4: the middle estimate sits 1.0-fold (0.02 log units) below what was measured; the range from low to high includes it.
By their numbers in this assay, from the lowest: compounds 1, 2 and 4 (each within the scatter of the next); then compound 3.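

On the aromatic carbon para to a large group, in this assay, chloro in place of methoxy gives no change at the digits printed from compound 2 to compound 4 (within the scatter) and chloro in place of bromo gives a 1.1-fold higher number from compound 1 to compound 4 (0.03 log units; within the scatter). Bromo, methoxy and chloro on this carbon now all lie within the scatter of one another, so the flat result extends beyond the single exchange seen before. No measurement available here explains this flatness. On these data alone, whether a carboxylic acid or a longer chain on this carbon would stay within the scatter remains open, and so does the role of the bromo on the shared core.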